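Thiophen-2-yl for furan-2-yl at the assay limit

This account rests on a few compounds, and the source may have more. Where it says the series, first, only, none or still open, it means among the compounds named here.

Measured so far in a functional assay on CWR22R cells (Homo sapiens) for antiproliferative activity, read by CCK-8 assay, with a stated time of 6 days; a lower number here means a stronger inhibitor, a higher number a weaker inhibitor:
- compound 1 (`N#Cc1ccc(N2CCc3cc(-c4cnc5ccccc5c4)ccc32)cc1C(F)(F)F`): "not determined" (no result reported)
- compound 2 (`N#Cc1ccc(N2CCc3cc(-c4cncnc4)ccc32)cc1C(F)(F)F`): "not determined" (no result reported)
- compound 3 (`CCN(c1ccc(C#N)c(Cl)c1)c1cc(-c2ccco2)ccc1C`): > 30000 nM (a limit of the assay, not a number)

Compound 3 is the only one of the three with a reported result, and that result is a limit and gives no single number. The position of the series in this assay therefore comes down to the limit of > 30000 nM in this assay, at which 1 of the 3 values shown sits, and to nothing finer. Among the measured compounds shown here, no step between measured compounds is available for comparison.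

Compound 4 (`CCN(c1ccc(C#N)c(Cl)c1)c1cc(-c2cccs2)ccc1C`) has thiophen-2-yl in place of furan-2-yl on an aromatic carbon. The expected change is an at least 1.2-fold lower number from compound 3 to compound 4 (0.07 log units; that floor lies within the scatter) and no step beyond the scatter is expected in either direction. This expectation rests on compound 3 alone, with its limit of > 30000 nM as the only reference. A further result at the limit is quite possible. For compound 4 the estimated value is 25000 nM with 8000 nM to 45000 nM as the expected range.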

Compound 4, half-maximal inhibitory concentration: 22000 nM
Estimate against measurement, compound 4: 1.1-fold (0.06 log units) above; measured number inside the range.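

In this assay compound 4 gives 22000 nM, the only single number shown for the series, so a five-membered aromatic ring at this position, para to a methyl group, can give a measurable result. Thiophen-2-yl in place of furan-2-yl reads as an at least 1.3-fold lower number from compound 3 to compound 4 (0.13 log units; that floor lies within the scatter), and this is a floor, so the true size of the step stays unknown. The reference for that step is a limit of the assay and not a number, the one held by compound 3: the limit of > 30000 nM in this assay, at which 1 of the 4 values shown sits.

The compounds shown leave open how far the step extends beyond that floor, since compound 1 and compound 2 have no reported result to add a comparison. Also open, on these data alone, is whether an amine or a carboxylic acid at this position would lower the number beyond the scatter.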